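Working notes: ring substituent change from compound 3 to compound 4

This account rests on a few compounds, and the source may have more. Where it says the series, first, only, none or still open, it means among the compounds named here.

compound 1, `Cc1ccc(-n2cc(-c3ccccc3NS(=O)(=O)c3c[nH]c(=O)[nH]c3=O)nn2)cc1`, 2190 nM
compound 2, `O=c1[nH]cc(S(=O)(=O)Nc2ccccc2-c2cn(-c3cccc(Cl)c3)nn2)c(=O)[nH]1`, 2180 nM
compound 3, `Cc1cccc(-n2cc(-c3cccc(NS(=O)(=O)c4c[nH]c(=O)[nH]c4=O)c3)nn2)c1`, 4080 nM

All three measured compounds were run in a functional assay on OVCAR-3 cells (Homo sapiens) for antiproliferative activity, read by MTT assay, with a stated time of 24 h; on this read-out lower numbers stand for stronger inhibition and higher numbers for weaker inhibition. Compound 3 gives the highest of the three numbers, but its gap to compound 1 and its gap to compound 2 both lie within the scatter, so no order among the three can be stated. Among the compounds with values here, the only single-point step among the measured compounds, a 1.0-fold lower number from compound 1 to compound 2 (0.00 log units; within the scatter), exchanges the aryl group on the aromatic nitrogen and gives no shift beyond the scatter.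

Compound 4, `O=c1[nH]cc(S(=O)(=O)Nc2cccc(-c3cn(-c4cccc(F)c4)nn3)c2)c(=O)[nH]1`, is still to be measured in this assay. Against compound 3 the change is fluoro in place of methyl on an aromatic carbon. Within the data shown here, no measured pair shows this exact exchange. The nearest comparison is the aryl swap on the same aromatic nitrogen between compound 1 and compound 2, which left the number unchanged within the scatter. On that basis the step of a 1.0-fold lower number from compound 3 to compound 4 (0.01 log units; within the scatter) is expected to remain within the scatter, with no direction claimed. Compound 4 is therefore estimated at 4000 nM in this assay, with an expected range from 2000 nM to 8000 nM.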

Compound 4, half-maximal inhibitory concentration: > 20000 nM
Compound 4: only a limit was reported; the forecaster's own chance of this, stated with the estimate: 5%; middle value at least 5.0-fold (0.69 log units) away from the limit.
By their numbers in this assay, from the lowest: compounds 2, 1 and 3 (each within the scatter of the next). At a limit, above all of these: compound 4.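

In this assay, exchanging 3-methylphenyl for 3-fluorophenyl, a change of one heavy atom on an aromatic carbon meta to a large group, gives an at least 4.9-fold higher number from compound 3 to compound 4 (0.69 log units; beyond the scatter), so the series does respond to a small change on this aryl group. The only earlier step on the aryl group, a 1.0-fold lower number from compound 1 to compound 2 (0.00 log units; within the scatter), showed no such response, but it belongs to a different pair, and this sensitivity is shown only for the pair of compound 3 and compound 4. Compound 4 gives a limit of the assay and not a number, so the printed step sets only a minimum size: the limit of > 20000 nM in this assay, at which 1 of the 4 values shown sits.

The compounds shown leave open whether this weakening follows from fluoro itself or from removing methyl, since only these two groups are compared on this carbon; an amine, a methoxy group or a carboxylic acid at the same place would help separate the two readings. They also give no measured property that could account for the step, and they do not show whether the same exchange would have a similar effect on the core of compound 1.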